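An Open Chain Gives Way to 4-Methylpiperazin-1-yl

A few compounds are considered here, and "the series" means these few. Any claim that something is new, unique, unknown or untested is made for them only; others in the source may bear on it.

Of the compounds shown here, three sharing one core have been tested in a functional assay on G-361 cells (Homo sapiens) for cytotoxicity, read by MTT assay, with a stated time of 3 days; a lower number here means a stronger inhibitor, a higher number a weaker inhibitor: compound 1 (`N#Cc1c(O)nc(SCc2nc3ccccc3[nH]2)nc1-c1ccccc1`) gives 3.43 nM, compound 2 (`N#Cc1c(NNC(N)=S)nc(SCc2nc3ccccc3[nH]2)nc1-c1ccccc1`) gives 3.96 nM and compound 3 (`N#Cc1c(NC(N)=S)nc(SCc2nc3ccccc3[nH]2)nc1-c1ccccc1`) gives 5.81 nM. Compound 3 thus stands within the scatter of both others, and the three cannot be ranked. Compound 4 (`CN1CCN(c2nc(SCc3nc4ccccc4[nH]3)nc(-c3ccccc3)c2C#N)CC1`) differs from compound 3 on an aromatic carbon, ortho to a cyano group: a group of 7 heavy atoms (5 carbon, 2 nitrogen; one six-membered non-aromatic ring with 2 hetero atoms) in place of a group of 4 heavy atoms (1 carbon, 2 nitrogen, 1 sulfur; no ring), on an aromatic carbon. Going by the values given here, three measured steps bear on this place: a 1.2-fold higher number from compound 1 to compound 2 (0.06 log units; within the scatter), a 1.7-fold higher number from compound 1 to compound 3 (0.23 log units; within the scatter) and a 1.5-fold higher number from compound 2 to compound 3 (0.17 log units; within the scatter). Each stays within the scatter, with a lone oxygen atom or an open chain at that carbon. None of these groups holds a ring, and the measurements do not show what a ring there would do, which leaves the expectation loose. No step beyond the scatter is therefore expected, and the estimated step is a 1.2-fold lower number from compound 3 to compound 4 (0.07 log units; within the scatter). For compound 4 the estimated value is 5 nM, with an expected range of 1.5 nM to 18 nM.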

Compound 4, half-maximal inhibitory concentration: 14.7 nM
Estimate against measurement, compound 4: 2.9-fold (0.47 log units) below; low and high end bracket the measured number.
By their numbers in this assay, from the lowest: compounds 1, 2 and 3 (each within the scatter of the next); then compound 4.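

Going by these compounds alone, at this carbon, ortho to a cyano group, 4-methylpiperazin-1-yl gives the first steps beyond the scatter in this assay: a 2.5-fold higher number from compound 3 to compound 4 (0.40 log units; beyond the scatter) and a 3.7-fold higher number from compound 2 to compound 4 (0.57 log units; beyond the scatter) against the two open chains, and a 4.3-fold higher number from compound 1 to compound 4 (0.63 log units; beyond the scatter) against hydroxy. Where hydroxy and the two open chains could not be ranked, this ring-bearing group separates from all three, leaving compound 4 the weakest of the set, though each step is only modest. Nothing available explains why this group gives a higher number than the others.

With one ring-bearing group at this carbon, the compounds shown leave open whether the step belongs to the ring itself, to its second nitrogen or to its methyl. A piperidin-1-yl, a morpholin-4-yl or an unsubstituted piperazin-1-yl there would separate these, and a plain amine would test whether any ring is needed for the step at all.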